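This account rests on a few compounds, and the source may have more. Where it says the series, first, only, none or still open, it means among the compounds named here.

Measured in an assay on LtK cells with ATP-sensitive inward rectifier potassium channel 11 (Homo sapiens) as the target; a higher number here means that more compound is needed for the effect, a lower number that less compound is needed:
compound 1, `O=C(CCc1ccccc1)Nc1c(C(O)(C(F)(F)F)C(F)(F)F)ccc2ccccc12`, 1750 nM
compound 2, `O=C(Nc1c(C(O)(C(F)(F)F)C(F)(F)F)ccc2ccccc12)c1ccccc1Cl`, 2040 nM

Compound 2 gives the higher of the two numbers in this assay, but the step of a 1.2-fold higher number from compound 1 to compound 2 (0.07 log units; within the scatter) is within the scatter, so the two compounds are not separated. Compound 3, `Cc1ccc(C(=O)Nc2c(C(O)(C(F)(F)F)C(F)(F)F)ccc3ccccc23)cc1`, differs from compound 2 in one place: 4-methylphenyl in place of 2-chlorophenyl on a carbonyl carbon. Within the data shown here, the only measured step touching the group on the carbonyl carbon is the one from compound 1 to compound 2, and it was small; it swapped phenethyl for 2-chlorophenyl rather than one substituted phenyl for another, so it bears only loosely on the present change. Among the measured compounds shown here, no measured pair compares two aryl groups on that carbonyl. Taken together, the one small step observed gives no ground to expect compound 3 to move far, and the step from compound 2 is estimated as a 1.0-fold lower number from compound 2 to compound 3 (0.01 log units; within the scatter), within the scatter. Compound 3 is therefore estimated at 2000 nM, with a range from 700 nM to 6000 nM.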

Compound 3, half-maximal effective concentration: 76 nM
Beside the measured number, compound 3's estimate is 26-fold (1.42 log units) above it; measured number outside the range, below it.
By their numbers in this assay, from the lowest: compound 3; then compounds 1 and 2 (each within the scatter of the next).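

In this assay the group on the carbonyl carbon can matter strongly: the change to 4-methylphenyl gives a 27-fold lower number from compound 2 to compound 3 (1.43 log units; beyond the scatter) and also a 23-fold lower number from compound 1 to compound 3 (1.36 log units; beyond the scatter), whereas the exchange of phenethyl for 2-chlorophenyl left compounds 1 and 2 unseparated. Two groups that both carry one six-membered aromatic ring of carbon only therefore need not behave alike at this position, and compound 3 stands clearly apart from both other compounds. No measurement at hand accounts for this difference.

The change alters both the substituent and its place on the ring, so the compounds shown do not tell which of the two goes with the lower number; 4-chlorophenyl and 2-methylphenyl would separate them. Also open, as far as these compounds go, is how unsubstituted phenyl, or 4-ethylphenyl with its longer chain, would compare with 4-methylphenyl.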